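Swapping one halogenated phenyl group on a shared core

This account rests on a few compounds, and the source may have more. Where it says the series, first, only, none or still open, it means among the compounds named here.

compound 1 `CNC(=O)c1cc(Oc2ccc(C3=NNC(c4cccc(Br)c4)C3)cc2)ccn1` 3540 nM
compound 2 `CNC(=O)c1cc(Oc2ccc(C3=NNC(c4cc(OC)c(OC)c(OC)c4)C3)cc2)ccn1` 28300 nM
compound 3 `CNC(=O)c1cc(Oc2ccc(C3=NNC(c4ccc(F)cc4Cl)C3)cc2)ccn1` 24300 nM

In a functional assay on PC-3 cells (Homo sapiens) for cytotoxicity, read by MTT assay, with a stated time of 72 h (a higher number here means a weaker inhibitor, a lower number a stronger inhibitor), compound 3 gives 24300 nM and lies within the scatter of compound 2 (28300 nM), while compound 1 (3540 nM) has the clearly lower number.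

Next comes compound 4 `CNC(=O)c1cc(Oc2ccc(C3=NNC(c4ccc(Cl)c(Cl)c4)C3)cc2)ccn1`, not yet measured, with 3,4-dichlorophenyl in place of 2-chloro-4-fluorophenyl on a saturated ring carbon. The rest of the molecule stays the same.

One measured step changes the group on that same carbon (a 6.9-fold higher number from compound 1 to compound 3 (0.84 log units; beyond the scatter)), and it is modest but beyond the scatter. The group names offer a weak hint: 3,4-dichlorophenyl carries a halogen numbered 3, as the 3-bromophenyl of compound 1 (3540 nM) does, whereas 2-chloro-4-fluorophenyl does not. A single step is thin evidence, so only part of that gap is expected to close. The expected move in this assay is a 2.7-fold lower number from compound 3 to compound 4 (0.43 log units; beyond the scatter) and points toward a lower number. The estimated value for compound 4 is 9000 nM with an expected range from 3000 nM to 26000 nM in repeat measurements.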

Compound 4, half-maximal inhibitory concentration: 36200 nM
Compound 4: the middle estimate sits 4.0-fold (0.60 log units) below what was measured, and the stated range ends below it.
By their numbers in this assay, from the lowest: compound 1; then compounds 3, 2 and 4 (each within the scatter of the next).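

Placing 3,4-dichlorophenyl on the saturated ring carbon in this assay gives a 1.5-fold higher number from compound 3 to compound 4 (0.17 log units; within the scatter) and so leaves the number within the scatter of the 2-chloro-4-fluorophenyl compound, even though the halogens on the two phenyl rings differ in both kind and numbered position. The same group gives a 10-fold higher number from compound 1 to compound 4 (1.01 log units; beyond the scatter) and this large gap shows that a halogen at the position numbered 3 does not by itself bring the low number of the 3-bromophenyl compound, as compound 4 has a chlorine there and stays far from compound 1. At this position, then, the two phenyl groups carrying two halogens cannot be told apart, while the single-bromine group of compound 1 stands clearly apart, and nothing available explains that difference.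

Going by these compounds, it remains open whether the lower number of compound 1 belongs to the bromine itself or to the presence of only one halogen on the phenyl ring. A 3-chlorophenyl group, a plain phenyl group or a 3-aminophenyl group on the same carbon would help to separate these readings.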